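The compounds below may be only part of what the source reports. "The series", "measured", "known", "first", "only" and "open" are said of these compounds alone.

The measured compounds stand as follows.
Compound 1, `CS(=O)(=O)c1ccc(C(=O)N2CCC(C(=O)N(Cc3ccccc3)c3ccccc3)CC2)cc1[N+](=O)[O-]`: in an assay on isolated protein for inhibition of thyroid hormone receptor beta (Homo sapiens), read by fluorescence polarization (on this read-out lower numbers stand for stronger inhibition and higher numbers for weaker inhibition), compound 1 gives > 60000 nM, which is a limit of the assay and not a number.
Compound 2, `CN(Cc1cccc(F)c1)C(=O)CCCNC(=O)c1ccc(S(C)(=O)=O)c([N+](=O)[O-])c1`: in this assay compound 2 gives > 60000 nM, again a limit.
Compound 3, `CS(=O)(=O)c1ccc(C(=O)NCCC(=O)N2CCCCC2)cc1[N+](=O)[O-]`: in this assay compound 3 gives > 60000 nM, a limit as well.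

Going by the values given here, compound 1 therefore has no number of its own in this assay; it sits at the same boundary as the other two compounds, and the one point of evidence is simply (the limit of > 60000 nM in this assay, at which 3 of the 3 values shown sit). Compound 4, `CN(Cc1ccccc1)C(=O)C1CCN(C(=O)c2ccc(S(C)(=O)=O)c([N+](=O)[O-])c2)CC1`, differs from compound 1 by methyl in place of phenyl on an amide-type nitrogen. Among the compounds with values here, no step between two measured compounds is available, so the size of the change has to be expected rather than read off. He expects a step that the limit leaves unreadable from compound 1 to compound 4, meaning no movement beyond the usual scatter, since every value so far is only a limit. For compound 4 in this assay he estimates 80000 nM, within 20000 nM to 300000 nM, and expects the result most likely to be reported once more as a limit.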

Compound 4, half-maximal inhibitory concentration: > 60000 nM
Compound 4 ended at the assay's limit (the forecaster's own chance of this, stated with the estimate: 85%); the middle value does not contradict the limit.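

Going by these compounds alone, compound 1 and compound 4 both stand only at a limit of the assay, so no step between them can be read: the limit of > 60000 nM in this assay, at which 4 of the 4 values shown sit.

The compounds shown leave open what number any of them would give in this assay, and which change to the shared core, if any, would bring a value inside the assay's range.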